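From hexyloxy to butylsulfanyl on a shared core

The source may hold more compounds than are shown below. What is called first, only, known or untested is meant among the compounds shown, and "the series" means these compounds.

Among the measured compounds shown here, in an ADME assay on CCRF-HSB-2 cells (Homo sapiens) for cytotoxicity, with a stated time of 7 days (on this read-out lower numbers stand for higher toxicity in this test and higher numbers for lower toxicity in this test), compound 1 (`CC(C)CSc1nc(N)nc2c1ncn2/C=C1/CC1(CO)CO`) gives 60000 nM as the only real number so far. Compound 2 (`Nc1nc(NC2CCCCC2)c2ncn(/C=C3/CC3(CO)CO)c2n1`) reads > 20000 nM, which is a limit. Compound 3 (`CCCCCCOc1nc(N)nc2c1ncn2/C=C1/CC1(CO)CO`) reads > 20000 nM, also a limit, so its standing is known only as the limit of > 20000 nM in this assay, at which 2 of the 3 values shown sit. Compound 4 (`CCCCSc1nc(N)nc2c1ncn2/C=C1/CC1(CO)CO`) brings butylsulfanyl in place of hexyloxy on an aromatic carbon. The measured steps give no size to carry over: a step that the limit leaves unreadable from compound 1 to compound 3 and a step that the two limits leave unreadable from compound 2 to compound 3. The best guide is compound 1 at 60000 nM, whose isobutylsulfanyl chain is the closest match to butylsulfanyl. The expected step is modest and keeps toxicity low (a step that the limit leaves unreadable from compound 3 to compound 4). For compound 4 the estimate is 40000 nM, with an expected range from 15000 nM to 100000 nM as its span.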

Compound 4, half-maximal cytotoxic concentration: 89000 nM
Compound 4: middle estimate off by 2.2-fold (0.35 log units), on the low side, and the stated range covers the measured number.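

In this assay, among the compounds shown here, compound 4 gives the first readable comparison at this position: swapping isobutylsulfanyl for butylsulfanyl is a 1.5-fold higher number from compound 1 to compound 4 (0.17 log units; within the scatter). The branched and straight sulfur-bound chains therefore cannot be told apart in this test. The steps from compound 2 and from compound 3 to compound 4 cannot be read, as those two compounds carry only limits: the limit of > 20000 nM in this assay, at which 2 of the 4 values shown sit.

Going by these compounds, it remains open how a shorter chain such as methylsulfanyl or a longer one such as octylsulfanyl would read on this carbon. On these data alone, whether butoxy would read like butylsulfanyl also remains open.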